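Sulfonamide nitrogen series: from compound 1 to compound 4

The source may report more compounds than this note shows. Statements on the series, on what has been measured and on what is new or still open speak of the compounds shown alone.

- compound 1 `CCc1ccc(N(C2COC2)S(=O)(=O)c2ccc3c(c2)C(O)CC(C2CCOCC2)O3)cc1` 2.63
- compound 2 `CC(C)CN(c1ccc(F)cc1)S(=O)(=O)c1ccc2c(c1)C(O)CC(C1CCOCC1)O2` 3.39
- compound 3 `CC(C)CN(c1cc2ccccc2s1)S(=O)(=O)c1ccc2c(c1)C(O)CC(C1CCOCC1)O2` 3.92

In a physicochemical assay for lipophilicity, at pH 7.4 (on this read-out higher numbers stand for higher lipophilicity and lower numbers for lower lipophilicity), compound 1 stands lowest of the three, and compound 2 and compound 3 both lie above it, beyond the scatter. Compound 4 `CCc1ccc(N(Cc2ccccc2)S(=O)(=O)c2ccc3c(c2)C(O)CC(C2CCOCC2)O3)cc1` is not yet measured. It carries benzyl in place of oxetan-3-yl on a sulfonamide nitrogen.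

Among the compounds with values here, the one measured single-place step also falls on a sulfonamide nitrogen and is modest (a number 0.53 log units higher from compound 2 to compound 3 (beyond the scatter)). That step exchanges 4-fluorophenyl for 1-benzothiophen-2-yl, so it is only a loose guide to an exchange of oxetan-3-yl for benzyl. Within the data shown here, no measured step covers the loss of oxetan-3-yl. Expected in this assay is an upward step, beyond the scatter and larger than that modest one (a number 1.57 log units higher from compound 1 to compound 4 (beyond the scatter)). This expectation places the new value in the neighbourhood of compound 3 (3.92). Compound 4 is estimated at 4.2 (expected range 3.7 to 4.7).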

Compound 4, distribution coefficient: 4.68
Compound 4: the middle estimate sits 0.48 log units below what was measured; the range from low to high includes it.
By their numbers in this assay, from the lowest: compound 1; then compound 2; then compound 3; then compound 4.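

In this assay, the exchange of oxetan-3-yl for benzyl on a sulfonamide nitrogen gives a number 2.05 log units higher from compound 1 to compound 4 (beyond the scatter) and is the only step shown that removes oxetan-3-yl. Rated large, it stands against the modest a number 0.53 log units higher from compound 2 to compound 3 (beyond the scatter) and shows that substituents on this nitrogen can shift the read-out well beyond what the exchange of 4-fluorophenyl for 1-benzothiophen-2-yl indicated. No measurement is available that explains the size of this step.

Going by these compounds, it remains open whether cyclohexylmethyl, a longer carbon chain, or a group carrying an amine or a carboxylic acid would fall near compound 1 or near compound 4 at this nitrogen. On these data alone, it is also open whether the same exchange keeps its size when 4-fluorophenyl or 1-benzothiophen-2-yl is the aromatic group on the nitrogen.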